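The source may report more compounds than this note shows. Statements on the series, on what has been measured and on what is new or still open speak of the compounds shown alone.

In a functional assay on SK-N-AS cells (Homo sapiens) for antiproliferative activity, with a stated time of 72 h (a higher number here means a weaker inhibitor, a lower number a stronger inhibitor), compound 3 (`Cc1ccc(CNC(=O)CCN(Cc2ccc(C(=O)NO)cc2)C(=O)c2ccc(N(C)C)cc2)cc1`) gives 340 nM, the lowest of the three numbers and beyond the scatter of both others: compound 1 (`Cc1cc(C)cc(C(=O)N(CCC(=O)NCc2ccccc2)Cc2ccc(C(=O)NO)cc2)c1`) gives 1860 nM and compound 2 (`O=C(CCN(Cc1ccc(C(=O)NO)cc1)C(=O)c1ccccc1)NCc1ccccc1`) gives 3310 nM. Compound 4 (`Cc1ccc(NC(=O)CCN(Cc2ccc(C(=O)NO)cc2)C(=O)c2ccc(N(C)C)cc2)cc1`) differs from compound 3 by 4-methylphenyl in place of 4-methylbenzyl on an amide-type nitrogen. Among the compounds with values here, the only measured step, a 1.8-fold higher number from compound 1 to compound 2 (0.25 log units; within the scatter), lies within the scatter and sits elsewhere, on a carbonyl carbon, so no measured step tests this change directly. No step beyond the scatter is therefore expected in this assay, and no direction is favoured. The estimated step is a 1.2-fold higher number from compound 3 to compound 4 (0.07 log units; within the scatter). Compound 4 is expected at 400 nM, within an estimated range of 130 nM to 1200 nM.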

Compound 4, half-maximal inhibitory concentration: 400 nM
Estimate against measurement, compound 4: no gap at the digits printed; measured number inside the range.
By their numbers in this assay, from the lowest: compounds 3 and 4 (each within the scatter of the next); then compounds 1 and 2 (each within the scatter of the next).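

In this assay, within the data shown here, replacing 4-methylbenzyl with 4-methylphenyl on the amide-type nitrogen gives a 1.2-fold higher number from compound 3 to compound 4 (0.07 log units; within the scatter), the first measured step at this position, and it shows that this shorter attachment of the aromatic ring leaves the number unchanged within the scatter. No measurement at hand explains this result. The compounds shown leave open whether a pyridyl ring, a carboxylic acid or a longer chain on this nitrogen would do the same. They also leave open whether the change behaves alike with phenyl or 3,5-dimethylphenyl on the carbonyl carbon.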